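The source may report more compounds than this note shows. Statements on the series, on what has been measured and on what is new or still open speak of the compounds shown alone.

Measured so far in a functional assay on ASPC1 cells (Homo sapiens) for inhibition, read by MTT assay, with a stated time of 72 h; a lower number here means a stronger inhibitor of growth, a higher number a weaker inhibitor of growth:
- compound 1, `O=S(=O)(NCCCNCc1ccc(C(F)(F)F)cc1)c1cc(C(F)(F)F)cc(C(F)(F)F)c1`: 2000 nM
- compound 2, `CN(CCCNS(=O)(=O)c1cc(C(F)(F)F)cc(C(F)(F)F)c1)Cc1ccccc1`: 51000 nM
- compound 3, `CC(C)(C)c1ccc(CNCCNS(=O)(=O)c2cc(C(F)(F)F)cc(C(F)(F)F)c2)cc1`: 14000 nM

Compound 1 gives the lowest number of the three in this assay. Compound 3 stands nearest to it, with a higher number that lies beyond the scatter, and compound 2 stands furthest, also beyond the scatter. Within the data shown here, no pair among the three differs in only one place, so none of these gaps can be read as a single step; they only show that compound 1 is the strongest growth inhibitor of the three measured.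

The next compound, compound 4, is `O=S(=O)(NCCCNCc1ccc(Cl)cc1)c1cc(C(F)(F)F)cc(C(F)(F)F)c1`. It differs from compound 1 in one place: chloro in place of trifluoromethyl on an aromatic carbon. The rest of the molecule, the three-carbon chain, the secondary amine and the sulfonamide on the shared core, is kept as in compound 1.

Among the measured compounds shown here, no measured step of this kind exists, so the expectation rests on compound 1 alone. A small step is expected in this assay, most likely toward a somewhat higher number, and possibly none beyond the scatter; the step from a 1.5-fold higher number from compound 1 to compound 4 (0.18 log units; within the scatter) is the estimate. For compound 4 the expected value in this assay is 3000 nM, with a range from 1000 nM to 10000 nM.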

Compound 4, concentration for 50% growth inhibition: 3000 nM
Compound 4: middle estimate and measured number agree at the digits printed; the measured number falls inside the stated range.
By their numbers in this assay, from the lowest: compounds 1 and 4 (each within the scatter of the next); then compound 3; then compound 2.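

In this assay the change from 4-(trifluoromethyl)benzyl to 4-chlorobenzyl gives a 1.5-fold higher number from compound 1 to compound 4 (0.18 log units; within the scatter) and so stays within the scatter; in this pair, trifluoromethyl and chloro on this aromatic carbon cannot be told apart, and trifluoromethyl is not needed there to keep the number of compound 1. Among these compounds, the change to (4-chlorobenzyl)amino in place of benzyl(methyl)amino gives a 17-fold lower number from compound 2 to compound 4 (1.23 log units; beyond the scatter) and is large, the first single step that lies beyond the scatter, but it joins the entry of chloro with the loss of the methyl on the amine, and this step alone cannot divide the gap between the two. Nothing measured here accounts for either step.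

Open, on these data alone, is whether a methoxy group, a nitrile or a carboxylic acid on the same aromatic carbon would also stay within the scatter of compound 1 and compound 4. Also open is how the methyl on the amine acts alone with the 4-chlorobenzyl group kept, and how a longer chain between the amine and the sulfonamide would read in this assay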